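Sulfanyl series notes: para-fluoro removal from compound 3

A few compounds are considered here, and "the series" means these few. Any claim that something is new, unique, unknown or untested is made for them only; others in the source may bear on it.

Measured compounds:
Compound 1 `CC(O)(CS(=O)(=O)c1ccc(Cl)cc1)c1nc(-c2ccc([N+](=O)[O-])c(C(F)(F)F)c2)no1` gives 91000 nM in a functional assay on DU-145 cells (Homo sapiens) for cytotoxicity, read by MTT assay; on this read-out lower numbers stand for stronger inhibition and higher numbers for weaker inhibition.
Compound 2 `CC(O)(CS(=O)(=O)c1ccccc1)c1nc(-c2ccc(Cl)cc2)no1` reaches only the assay limit > 100000 nM in this assay.
Compound 3 `CC(O)(CSc1ccc(F)cc1)c1nc(-c2ccc([N+](=O)[O-])c(C(F)(F)F)c2)no1` gives 5100 nM in this assay.

Compound 3 holds the lowest number of the two values that are numbers; its nearest neighbour is compound 1, reached through an 18-fold lower number from compound 1 to compound 3 (1.25 log units; beyond the scatter). That step swaps two features at once, the sulfonyl for sulfanyl and chloro for fluoro, so it does not isolate the para substituent of the pendant ring. Among the compounds with values here, compound 2 sits at a limit of > 100000 nM in this assay, at which 1 of the 3 values shown sits, and differs from the others in more than one place, so it offers no step to read.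

Compound 4 `CC(O)(CSc1ccccc1)c1nc(-c2ccc([N+](=O)[O-])c(C(F)(F)F)c2)no1` is the next member. The change from compound 3 is hydrogen in place of fluoro on an aromatic carbon, para to the large group. Within the data shown here, no measured step in this set isolates that change. Compound 4 is therefore expected to stay close to compound 3 in this assay, with a 1.3-fold higher number from compound 3 to compound 4 (0.11 log units; within the scatter) not beyond the scatter. The estimate for compound 4 is 6500 nM, within 2500 nM to 17000 nM.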

Compound 4, half-maximal inhibitory concentration: 3000 nM
Compound 4: the middle estimate sits 2.2-fold (0.34 log units) above what was measured; low and high end bracket the measured number.
By their numbers in this assay, from the lowest: compounds 4 and 3 (each within the scatter of the next); then compound 1. At a limit, above all of these: compound 2.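

In this assay, within the data shown here, replacing fluoro with hydrogen on the aromatic carbon para to a large group gives a 1.7-fold lower number from compound 3 to compound 4 (0.23 log units; within the scatter), the first step that isolates this position, and on this pair the sulfanyl compounds do not separate fluoro from hydrogen there. The wider step, a 30-fold lower number from compound 1 to compound 4 (1.48 log units; beyond the scatter), changes the sulfur link and removes the chloro together, so it cannot be assigned to either change alone, although it shows that the large gap to the sulfonyl compound 1 holds for both sulfanyl compounds. Nothing shown gives a cause for either step.

Still open, as far as these compounds go, is whether the same aromatic carbon stays this undiscriminating with a larger or different group, such as methoxy or a dimethylamino group, since only fluoro and hydrogen are compared there on a sulfanyl link. Also open, from the compounds shown here alone, is how much of the gap belongs to the sulfur link itself, which a sulfonyl or sulfinyl counterpart of compound 4, with the same phenyl and the same core, would settle.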